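This account rests on a few compounds, and the source may have more. Where it says the series, first, only, none or still open, it means among the compounds named here.

Series values in a functional assay on B16-F10 cells (Mus musculus) for antiproliferative activity, read by MTT assay, with a stated time of 48 h; a lower number here means a stronger inhibitor, a higher number a weaker inhibitor:
- compound 1 `COc1ccc(/C=C/c2cc(OC)cc(OC)c2/C=C/C(=O)c2cccc(Br)c2)cc1`: 5.1 ug/mL
- compound 2 `COc1ccc(/C=C/c2cc(OC)cc(OC)c2/C=C/C(=O)c2ccc(C(F)(F)F)cc2)cc1`: 4.3 ug/mL

Among the measured compounds shown here, compound 2 has only one measured neighbour, compound 1, and the two values lie within the scatter of each other, so neither compound can be ranked ahead. The next compound to be tested in this assay is compound 3 `CCOc1ccc(C(=O)/C=C/c2c(/C=C/c3ccc(OC)cc3)cc(OC)cc2OC)cc1`, which replaces 4-(trifluoromethyl)phenyl with 4-ethoxyphenyl: ethoxy in place of trifluoromethyl on an aromatic carbon, para to a large group (ethoxy in place of trifluoromethyl on an aromatic carbon).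

For the measured compounds named here, one measured step bears on this change, as it also concerns the group on a carbonyl carbon. That step, a 1.2-fold lower number from compound 1 to compound 2 (0.07 log units; within the scatter), stays within the scatter. Going by the values given here, it is only a weak guide, since no measured compound carries ethoxy and neither measured compound tests this exchange directly. On the evidence of compound 2 at 4.3 ug/mL and that small step, no change beyond the scatter is expected. For compound 3 the estimated value is 5 ug/mL, with an expected range of 2.5 ug/mL to 10 ug/mL. This estimate corresponds to an expected 1.2-fold higher number from compound 2 to compound 3 (0.07 log units; within the scatter).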

Compound 3, half-maximal inhibitory concentration: 6.4 ug/mL
Estimate against measurement, compound 3: 1.3-fold (0.11 log units) below; the measured number falls inside the stated range.
By their numbers in this assay, from the lowest: compounds 2, 1 and 3 (each within the scatter of the next).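

In this assay, the exchange of trifluoromethyl for ethoxy on an aromatic carbon, para to a large group, gives a 1.5-fold higher number from compound 2 to compound 3 (0.17 log units; within the scatter), so the first direct test at this place does not separate the two groups, even though ethoxy brings in a hydrogen-bond acceptor that trifluoromethyl lacks. The wider comparison on the carbonyl carbon, a 1.3-fold higher number from compound 1 to compound 3 (0.10 log units; within the scatter), also stays inside the scatter, so 3-bromophenyl, 4-(trifluoromethyl)phenyl and 4-ethoxyphenyl cannot be ranked against one another in this series, and none of the three groups stands out on the shared core. No measurement is available to explain this result or to say what the ring substituent contributes.

As far as these compounds go, whether an amine or a carboxylic acid at this place, or a chain longer than ethoxy such as butoxy, would move the number beyond the scatter remains open. All three compounds also share one core, so they give no information on how changes to the methoxy groups or the styryl part would read in this assay.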